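Carbamate Ester Change in a Spirocyclic Sulfone Series

This account rests on a few compounds, and the source may have more. Where it says the series, first, only, none or still open, it means among the compounds named here.

Measured compounds:
Compound 1 `CC(C)(C)OC(=O)N1CCC2(CC1)CC2CCOc1ccc(S(C)(=O)=O)cc1`: 2390 nM
Compound 2 `CC(C)(C)OC(=O)N1CCC2(CC1)CC(CCCOc1ccc(S(C)(=O)=O)c(F)c1)C2`: 9 nM
Compound 3 `CC(C)(C)OC(=O)N1CCC2(CC1)CC(CCCCOc1ccc(S(C)(=O)=O)cc1)C2`: 154 nM

All three were tested in a functional assay on cells for agonist activity at Glucose-dependent insulinotropic receptor (Homo sapiens), read by HTRF and cAMP accumulation, with a stated time of 30 min; a lower number here means that less compound is needed, a higher number that more compound is needed for the effect. Compound 2 gives the lowest number of the three, 9 nM; compound 3 is the nearest to it and compound 1 the furthest, both beyond the usual scatter. Compound 4 `CC(C)(C)COC(=O)N1CCC2(CC1)CC(CCCOc1ccc(S(C)(=O)=O)c(F)c1)C2` is not yet measured. It differs from compound 2 in one place: neopentyl in place of tert-butyl on an oxygen next to a carbonyl group. This is a small change at the end of the molecule that carries the carbamate, far from the sulfone-bearing ring where the measured compounds vary. Among the compounds with values here, no measured pair shows this exact change, so the expected step from compound 2 to compound 4 is estimated as a 1.7-fold higher number from compound 2 to compound 4 (0.22 log units; within the scatter), likely within or only slightly beyond the scatter. The estimate for compound 4 is therefore 15 nM, with a range from 4 nM to 60 nM.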

Compound 4, half-maximal effective concentration: 31 nM
Compound 4: the middle estimate sits 2.1-fold (0.32 log units) below what was measured, and the stated range covers the measured number.
By their numbers in this assay, from the lowest: compound 2; then compound 4; then compound 3; then compound 1.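

In this assay, neopentyl in place of tert-butyl on an oxygen next to a carbonyl group gives a 3.4-fold higher number from compound 2 to compound 4 (0.54 log units; beyond the scatter), the first step seen at this end of the molecule. One extra carbon, with no ring, donor or acceptor gained, is enough to move the number, so this position is sensitive to the group it carries. Nothing available explains why the number moves. Still open, as far as these compounds go, is how smaller or ring-bearing groups on this oxygen, such as isopropyl or cyclobutyl, would compare. Also open, from the compounds shown here alone, is whether the same step appears with the other chains.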